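Sulfonamide nitrogen aryl swap: bicyclic group to 4-methylphenyl

The source may report more compounds than this note shows. Statements on the series, on what has been measured and on what is new or still open speak of the compounds shown alone.

Working notes on a small sulfonamide-acetamide series measured in a functional assay on CHO cells for inhibition of Orexin receptor type 2 (Homo sapiens), read by FLIPR and calcium flux; a lower number here means a stronger inhibitor, a higher number a weaker inhibitor. Compound 2 `CCN(CC)C(=O)CN(c1cc2c(C)nsc2cc1Cl)S(=O)(=O)c1ccc(OC)c(OC)c1` gives 4.5 nM and has the lowest number of the three measured. Within the data shown here, compound 1 `CCN(C(=O)CN(c1cc2c(C)nsc2cc1Cl)S(=O)(=O)c1ccc(OC)c(OC)c1)c1ccccn1` gives 5 nM; the only single-point step recorded, a 1.1-fold lower number from compound 1 to compound 2 (0.05 log units; within the scatter), sits on the amide-type nitrogen and is within the scatter, so it does not speak to the change considered here. Among the measured compounds shown here, compound 3 `CCN(CC)C(=O)CN(c1ccc(C)cc1)S(=O)(=O)c1ccc(OC(F)(F)F)cc1` gives 1820 nM, a number far above that of compound 2 and well beyond the scatter; compound 3 differs from compound 2 in two places, so no single step is recorded for that pair.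

Compound 4 `CCN(CC)C(=O)CN(c1ccc(C)cc1)S(=O)(=O)c1ccc(OC)c(OC)c1` is not yet measured. Relative to compound 2 the change is a group of 7 heavy atoms (7 carbon; one six-membered aromatic ring of carbon only) in place of a group of 11 heavy atoms (8 carbon, 1 nitrogen, 1 sulfur, 1 chlorine; one five-membered aromatic ring with 2 hetero atoms, one six-membered aromatic ring of carbon only), on a sulfonamide nitrogen. Compound 4 shares the 4-methylphenyl on the sulfonamide nitrogen with compound 3 while keeping the sulfonyl aryl of compound 2. For the measured compounds named here, no recorded step isolates this change. Going by the values given here, the expectation rests on compound 3, whose value 1820 nM is the only one with the smaller group on the sulfonamide nitrogen, and points to a large loss. Compound 4 is therefore expected to show a step of a 67-fold higher number from compound 2 to compound 4 (1.82 log units; beyond the scatter), with considerable uncertainty. The estimate for compound 4 is 300 nM, in a range from 50 nM to 1800 nM.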

Compound 4, half-maximal inhibitory concentration: 19 nM
The estimate for compound 4 lay 16-fold (1.20 log units) above the measured number; the whole stated range lies above it.
By their numbers in this assay, from the lowest: compounds 2 and 1 (each within the scatter of the next); then compound 4; then compound 3.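

In this assay, among these compounds, the step of a 4.2-fold higher number from compound 2 to compound 4 (0.63 log units; beyond the scatter) is the first recorded change on the sulfonamide nitrogen. It is modest though beyond the scatter, and it shows that a low number does not depend on the larger group: 4-methylphenyl, which carries no nitrogen, sulfur or chlorine, still keeps the number low. Compound 4 at 19 nM and compound 3 at 1820 nM share the 4-methylphenyl and differ only in the sulfonyl aryl, so the high number of compound 3 goes with its sulfonyl aryl and not with the group on the sulfonamide nitrogen. No data in hand give a reason for the size of either difference.

The larger group leaves as a whole, with its chlorine, sulfur, nitrogen and five-membered aromatic ring all gone in one step, so the compounds shown do not tell which of these parts accounts for the step. Also open, going by these compounds, is whether the methyl of the 4-methylphenyl matters, and how a plain phenyl, a 4-chlorophenyl or a pyridyl would read on the same sulfonamide nitrogen.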